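Replacing the Ester Side Chain of a Kinase Inhibitor

The source may report more compounds than this note shows. Statements on the series, on what has been measured and on what is new or still open speak of the compounds shown alone.

Of the compounds shown here, two have so far been measured in an assay on isolated protein for inhibition of Rho-associated protein kinase 2 (Homo sapiens), read by radiometric assay; on this read-out lower numbers stand for stronger inhibition and higher numbers for weaker inhibition. Compound 1 `CCCCCCOC(=O)c1cccc(-c2cc(C(=O)Nc3ccncc3)ccc2CN)c1` gives 22 nM in this assay. Compound 2 `NCc1ccc(C(=O)Nc2ccncc2F)cc1-c1cccc(C(=O)OCCO)c1` gives 1.4 nM in this assay, the lowest of the two numbers, and its gap to compound 1 lies beyond the usual scatter. Compound 3 `NCc1ccc(C(=O)Nc2ccncc2F)cc1-c1cccc(C(=O)OC2CCCOC2)c1` has not yet been measured. It differs from compound 2 in one place: oxan-3-yl in place of 2-hydroxyethyl on an oxygen next to a carbonyl group. Within the data shown here, no pair of measured compounds differing in only one place is available, so there is no measured step to lean on, and compound 1 differs from compound 2 in more than one place. The step from compound 2 to compound 3 is expected to be small, at most a modest weakening, a 2.1-fold higher number from compound 2 to compound 3 (0.33 log units; beyond the scatter). Compound 3 is therefore expected to come in at 3 nM, with a range from 1 nM to 10 nM.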

Compound 3, half-maximal inhibitory concentration: 8.7 nM
For compound 3 the middle estimate is 2.9-fold (0.46 log units) below the measured one; the range from low to high includes it.
By their numbers in this assay, from the lowest: compound 2; then compound 3; then compound 1.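

Among these compounds, exchanging 2-hydroxyethyl for oxan-3-yl on the oxygen next to a carbonyl group gives a 6.2-fold higher number from compound 2 to compound 3 (0.79 log units; beyond the scatter) in this assay, the first measured step at this position, so the position accepts a six-membered non-aromatic ring at a modest cost. The change brings in the ring, adds heavy atoms and removes the hydrogen-bond donor all at once, and this single step cannot separate these differences. Nothing measured here accounts for the size of the step.

As far as these compounds go, it remains open whether the ring or the missing hydrogen-bond donor matters more, which 2-methoxyethyl or oxan-4-yl on the same oxygen could help to separate. Also open, from the compounds shown here alone, is how a carboxylic acid in place of the ester would read in this assay, with the rest of compound 2 unchanged.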